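Propyl in place of hydrogen on a quinoline-sulfonamide beta-glucuronidase series

The source may report more compounds than this note shows. Statements on the series, on what has been measured and on what is new or still open speak of the compounds shown alone.

Compound 1, `O=[N+]([O-])c1ccccc1S(=O)(=O)Nc1cnc2ccccc2c1`: 8100 nM
Compound 2, `O=[N+]([O-])c1ccc(S(=O)(=O)Nc2cnc3ccccc3c2)cc1`: 31600 nM
Compound 3, `O=S(=O)(Nc1cnc2ccccc2c1)c1ccccc1`: 53400 nM

Three sulfonamides of the shared core have been measured in an assay for inhibition of beta-glucuronidase (Bos taurus), read by spectrophotometry, with a stated time of 30 min; on this read-out lower numbers stand for stronger inhibition and higher numbers for weaker inhibition. Compound 3, the unsubstituted phenyl member, stands at the highest number of the three; its nearest neighbour is compound 2, and its furthest is compound 1. Both measured steps concern the removal of a nitro group: a 6.6-fold higher number from compound 1 to compound 3 (0.82 log units; beyond the scatter), whereas a 1.7-fold higher number from compound 2 to compound 3 (0.23 log units; within the scatter). So removing the nitro from the ring of compound 1 costs potency, while removing it from the ring of compound 2 makes no clear difference.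

Compound 4, `CCCc1ccc(S(=O)(=O)Nc2cnc3ccccc3c2)cc1`, is not yet measured. It differs from compound 3 by propyl in place of hydrogen on an aromatic carbon. Neither measured step involves a propyl group or any other carbon chain, so they bear on this change only indirectly, through what they show about substitution para to the large group: compound 2 and compound 3 lie within the scatter of each other. On that basis the step is expected to be small, a 1.5-fold lower number from compound 3 to compound 4 (0.18 log units; within the scatter), in either direction or none beyond the scatter. Compound 4 is therefore estimated at 35000 nM in this assay, with a range from 9000 nM to 120000 nM.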

Compound 4, half-maximal inhibitory concentration: 27200 nM
Compound 4: the middle estimate sits 1.3-fold (0.11 log units) above what was measured; the measured number falls inside the stated range.
By their numbers in this assay, from the lowest: compound 1; then compounds 4, 2 and 3 (each within the scatter of the next).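

In this assay, propyl in place of hydrogen on an aromatic carbon, para to a large group, gives a 2.0-fold lower number from compound 3 to compound 4 (0.29 log units; within the scatter), so the first carbon chain at this position makes no clear difference to the number. Propyl in place of nitro at the same position gives a 1.2-fold lower number from compound 2 to compound 4 (0.07 log units; within the scatter), which means that compound 2, compound 3 and compound 4 cannot be told apart in this assay, whether the position carries hydrogen, nitro or propyl. The data offer no independent measurement that would explain why these three groups give such similar numbers.

The compounds shown leave open whether any group at this position can move the number beyond the scatter, for instance an amine, a carboxylic acid or a longer chain such as hexyl. They also leave open whether propyl would match nitro at the place that the nitro group holds in compound 1, the one place in this set where removing a group gave a step beyond the scatter.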